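Swapping Hydrogen for Chloro on a Phenyl Ring

This account rests on a few compounds, and the source may have more. Where it says the series, first, only, none or still open, it means among the compounds named here.

Of the compounds shown here, two have so far been tested in a functional assay on the whole organism (strain albino) for inhibition, with Rattus norvegicus as the target, read by paw edema, with stated times of 30 min and 4 h, at a dose of 25 mg/kg by the intraperitoneal route; on this read-out higher numbers stand for more inhibition at the one dose given (going by the name of the read-out) and lower numbers for less inhibition. Compound 1 `CCOC(=O)c1nn(-c2ccccc2)c(-c2ccc(OC)cc2OC)c1-c1ccccc1` gives 20.2% in this assay. Compound 2 `COc1ccc(C2=NN(C(=S)NC(=O)c3ccc(Cl)cc3)CC2c2ccccc2)c(OC)c1` gives 1.92% in this assay. Of these two numbers, compound 1 stands highest, and its gap to compound 2 lies beyond the usual scatter. The two compounds differ in several places at once, so no single structural change can be tied to that gap.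

Compound 3 `CCOC(=O)c1nn(-c2ccc(Cl)cc2)c(-c2ccc(OC)cc2OC)c1-c1ccccc1` is not yet measured. It differs from compound 1 in one place: chloro in place of hydrogen on an aromatic carbon. Put another way, a phenyl becomes a 4-chlorophenyl.

Within the data shown here, no measured pair here shows what such a change does in this assay, so there is nothing to lean on beyond the value of compound 1. The expectation is therefore a step from compound 1 to compound 3 of about a number 1.8 percentage points higher from compound 1 to compound 3 (within the scatter), that is, no change beyond the scatter in either direction. On that basis compound 3 is expected to give roughly 22%, with a plausible range from 8% to 40%.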

Compound 3, a percentage reported as inhibition, in the whole organism at one dose (the size of the read-out at that dose, not a potency): 15.4%
Beside the measured number, compound 3's estimate is 6.6 percentage points above it; measured number inside the range.
By their numbers in this assay, from the lowest: compound 2; then compounds 3 and 1 (each within the scatter of the next).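

Among these compounds, this is the first pair in this assay that differs in only one place, so the change from phenyl to 4-chlorophenyl can now be read directly: the step is a number 4.8 percentage points lower from compound 1 to compound 3 (within the scatter) and so does not separate the two compounds. At this position, on an aromatic carbon para to a large group, chloro in place of hydrogen therefore leaves the inhibition at this one dose indistinguishable from that of the hydrogen compound, a finding that rests on this single pair. No evidence is available that would explain this result or link it to any property of the chloro group.

What the compounds shown leave open is whether a different group at this same position, such as an amine or a carboxylic acid, would move the number beyond the usual scatter. Going by these compounds, it also remains open whether chloro in place of hydrogen elsewhere on the shared core would give a similar result, and whether this position would behave the same way at other doses.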